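Chain extension on the amine in the biaryl series

The source may report more compounds than this note shows. Statements on the series, on what has been measured and on what is new or still open speak of the compounds shown alone.

In an assay on isolated protein for binding affinity to 5-hydroxytryptamine receptor 1D (Homo sapiens) (on this read-out lower numbers stand for stronger inhibition and higher numbers for weaker inhibition), compound 1 `COc1ccccc1-c1cc(C2CCNC2)ccc1Cl` gives 3.4 nM. Compound 2 `CNCc1ccc(Cl)c(-c2ccccc2OC)c1` gives 1200 nM in this assay, and compound 3 `CCNCc1ccc(Cl)c(-c2ccccc2OC)c1` gives 220 nM in this assay. Compound 3 therefore stands second highest of the three numbers: its nearest neighbour is compound 2, since a 5.5-fold lower number from compound 2 to compound 3 (0.74 log units; beyond the scatter), and its furthest is compound 1, since a 65-fold higher number from compound 1 to compound 3 (1.81 log units; beyond the scatter). Compound 1 is the strongest of the three, as both a 350-fold higher number from compound 1 to compound 2 (2.55 log units; beyond the scatter) and a 65-fold higher number from compound 1 to compound 3 (1.81 log units; beyond the scatter) lie beyond the scatter.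

Compound 4 `CCCNCc1ccc(Cl)c(-c2ccccc2OC)c1` differs from compound 3 by methyl in place of hydrogen on a saturated chain carbon, two bonds along the chain from an amine nitrogen, so that ethylamino becomes propylamino. Among the compounds with values here, the one measured step that bears on this is a 5.5-fold lower number from compound 2 to compound 3 (0.74 log units; beyond the scatter), the same kind of lengthening taken one bond nearer the amine nitrogen, and it was modest. The steps from compound 1 to the acyclic amines were large but concern a different change and give no guide to further lengthening. A smaller step in the same direction, toward a lower number in this assay, is expected, though it may not clear the scatter. Compound 4 is estimated at 120 nM, within a range from 40 nM to 400 nM. The expected step is a 1.8-fold lower number from compound 3 to compound 4 (0.26 log units; within the scatter).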

Compound 4, inhibition constant: 220 nM
For compound 4 the middle estimate is 1.8-fold (0.26 log units) below the measured one; measured number inside the range.
By their numbers in this assay, from the lowest: compound 1; then compounds 3 and 4 (each within the scatter of the next); then compound 2.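

In this assay, going from ethylamino to propylamino on a saturated chain carbon, two bonds along the chain from an amine nitrogen, gives no measurable return (no change at the digits printed from compound 3 to compound 4 (within the scatter)), so the lengthening step seen one bond nearer that nitrogen does not repeat at this place. Both longer chains stand at the same distance from the methylamino compound, as the step to propylamino (a 5.5-fold lower number from compound 2 to compound 4 (0.74 log units; beyond the scatter)) reads the same as the step to ethylamino (a 5.5-fold lower number from compound 2 to compound 3 (0.74 log units; beyond the scatter)), and the propylamino chain leaves the large gap to the pyrrolidin-3-yl compound in place (a 65-fold higher number from compound 1 to compound 4 (1.81 log units; beyond the scatter)). Nothing measured on these compounds accounts for the lack of response to the added methyl.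

Going by these compounds, whether butylamino or a longer chain would stay level with propylamino or move away from it remains open, as does the outcome of a branched isopropylamino group or a dimethylamino group at the same nitrogen. The compounds shown also leave open whether any open-chain amine on this core can approach the pyrrolidin-3-yl compound, or whether a ring such as azetidine or piperidine would be needed.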